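The source may report more compounds than this note shows. Statements on the series, on what has been measured and on what is new or still open speak of the compounds shown alone.

Measured so far in a functional assay on MCF7 cells (Homo sapiens) for antiproliferative activity, read by sulforhodamine B assay, with a stated time of 72 h, tested at 10 uM; on this read-out higher numbers stand for a weaker effect at the one concentration tested and lower numbers for a stronger effect:
- compound 1, `COc1cc(Br)cc(/C=C/C(=O)c2ccccc2)c1O`: 67%
- compound 2, `COc1cccc(C(=O)/C=C/c2cc(Br)cc(OC)c2O)c1`: 77.3%
- compound 3, `O=C(/C=C/c1cc(Br)ccc1O)c1ccc(Br)cc1`: 28.7%

Compound 1 and compound 2 differ in one place, (methoxy in place of hydrogen on an aromatic carbon), and this gave a number 10.3 percentage points higher from compound 1 to compound 2 (beyond the scatter). Compound 3 stands lowest of the three numbers; its nearest neighbour is compound 1 and its furthest compound 2, both gaps beyond the scatter. The difference between the core of compound 3 and the core of compound 1 is not broken down here.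

Compound 4, `COc1cc(Br)cc(/C=C/C(=O)c2ccc(Br)cc2)c1O`, has not yet been tested in this assay. It differs from compound 3 by methoxy in place of hydrogen on an aromatic carbon. Among the compounds with values here, this is the same kind of change as the one from compound 1 to compound 2, not the same: around the place in compound 3 the entering group sits ortho to a hydroxy group and meta to a bromo group as well as meta to a large group, whereas in compound 1 the place is told only as meta to a large group.

Within the data shown here, the only measured instance of this kind of change is the modest rise seen as a number 10.3 percentage points higher from compound 1 to compound 2 (beyond the scatter), on a different core. A step of similar direction and size is expected from compound 3 to compound 4, a number 9.3 percentage points higher from compound 3 to compound 4 (within the scatter), resting on that one instance alone and so held loosely. For compound 4 in this assay the estimate is 38%, with a range from 26% to 52%.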

Compound 4, a percentage reported as activity, at one concentration (the size of the read-out at that concentration, not a potency): 64.6%
Compound 4: the middle estimate sits 26.6 percentage points below what was measured; measured number outside the range, above it.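

Methoxy in place of hydrogen on an aromatic carbon moves the number the same way on both cores in this assay, toward a weaker effect, but the size of the step does not carry over: the same change on two cores in this assay, a number 10.3 percentage points higher (beyond the scatter) from compound 1 to compound 2 and a number 35.9 percentage points higher (beyond the scatter) from compound 3 to compound 4, 25.6 percentage points apart, beyond the scatter of two such steps.

On the core of compound 3 the change gives a number 35.9 percentage points higher from compound 3 to compound 4 (beyond the scatter), and bromo in place of hydrogen on an aromatic carbon gives a number 2.4 percentage points lower from compound 1 to compound 4 (within the scatter), so the strong effect of compound 3 is not kept once the methoxy enters and the bromo swap shows no readable change on this pair. Two instances show a repeated direction and no rule for the size, and they cannot separate the core from the place, since the methoxy in compound 4 sits ortho to a hydroxy group and meta to a bromo group as well as meta to a large group, while the place in compound 2 is told only as meta to a large group.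

Going by these compounds, whether an ethoxy group, a longer chain, an amine or a carboxylic acid at the same place on the core of compound 3 would weaken the effect as methoxy does stays open. With one concentration per compound, these numbers tell only how strong or weak the effect is at that concentration.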